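Adding one methyl group to compound 1

The source may report more compounds than this note shows. Statements on the series, on what has been measured and on what is new or still open speak of the compounds shown alone.

compound 1 `COC(=O)Nc1cc(-c2ccc(OC[C@@](C)(N)CC(C)C)cn2)ccn1` gives 100%
compound 2 `COC(=O)Nc1cc(-c2ccc(OC[C@@](C)(N)CC(C)C)nc2)ccn1` gives 96%
compound 3 `COC(=O)Nc1cc(-c2ccc(OC[C@@](C)(N)CC(C)C)c(Cl)n2)ccn1` gives 99%

All three compounds were tested in an ADME assay on microsomes from liver (Rattus norvegicus) for metabolic stability, read by LC-MS, using NADPH, with a stated time of 10 min, tested at 0.5 uM; on this read-out higher numbers stand for a more stable compound and lower numbers for a less stable compound. Compound 1 sits level with compound 2 and compound 3. Their values lie within the scatter of one another and cannot be ranked.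

Compound 4 `COC(=O)Nc1cc(-c2cc(C)c(OC[C@@](C)(N)CC(C)C)cn2)ccn1` has not been measured yet. It is compound 1 with a single change, methyl in place of hydrogen on an aromatic carbon, ortho to the (2-amino-2,4-dimethylpentyl)oxy group: methyl in place of hydrogen on an aromatic carbon.

The closest measured step is chloro in place of hydrogen on an aromatic carbon, a number 1 percentage points lower from compound 1 to compound 3 (within the scatter). For the measured compounds named here, it involves a different group, and no step that adds methyl has been measured, so it is only a rough guide. It gives no reason to expect a change beyond the scatter in this assay. The expected step is a number 4 percentage points lower from compound 1 to compound 4 (within the scatter), which is no larger than the scatter. For compound 4 the estimated value is 96%, with an expected range from 84% to 100%.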

Compound 4, percent of the compound remaining: 100%
Compound 4: the middle estimate sits 4 percentage points below what was measured; the measured number falls inside the stated range.
By their numbers in this assay, from the lowest: compounds 2, 3, 1 and 4 (each within the scatter of the next).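

In this assay, for the compounds shown here, the first step that adds methyl, placed ortho to the (2-amino-2,4-dimethylpentyl)oxy group and opposite the ring nitrogen, reads no change at the digits printed from compound 1 to compound 4 (within the scatter) and so shows that this position accepts one added carbon without a measurable loss of stability. With compound 1 already at 100% the read-out leaves no room to show a gain here, so the result can only speak against a loss. No measurement available here accounts for this outcome.

Going by these compounds, whether a bulkier group at this position, such as isopropyl or phenyl, or a group such as an amine or a carboxylic acid, would leave the number in place stays open. No value in this set lies beyond the scatter of another, so the compounds shown do not reveal what change to the shared core would lower it.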